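A few compounds are considered here, and "the series" means these few. Any claim that something is new, unique, unknown or untested is made for them only; others in the source may bear on it.

Three compounds sharing one core differ only in the ester that ends the side chain. Compound 1 `CCOc1cc(NC(=O)C2(NC(=O)c3ccc4c(C5CCCC5)c(-c5ncc(Cl)cn5)n(C)c4c3)CCC2)ccc1/C=C/C(=O)OC(=O)C[C@H](O)C(=O)O` lasts longest in an ADME assay (liver) for pharmacokinetics, with Liver microsome (Rattus norvegicus) as the target, using microsomes (a lower number here means that the compound disappears faster, a higher number that the compound lasts longer), with a half-life of 7.92 h. Compound 2 `CCOc1cc(NC(=O)C2(NC(=O)c3ccc4c(C5CCCC5)c(-c5ncc(Cl)cn5)n(C)c4c3)CCC2)ccc1/C=C/C(=O)OCOP(=O)(O)O` gives 0.15 h in this assay, and compound 3 `CCCOC(=O)/C=C/c1ccc(NC(=O)C2(NC(=O)c3ccc4c(C5CCCC5)c(-c5ncc(Cl)cn5)n(C)c4c3)CCC2)cc1OCC` gives 0.35 h. The swap from compound 1 to compound 2 brings a 53-fold lower number from compound 1 to compound 2 (1.72 log units; beyond the scatter), and that from compound 1 to compound 3 brings a 23-fold lower number from compound 1 to compound 3 (1.35 log units; beyond the scatter); between the two shorter-lived esters the step is a 2.3-fold higher number from compound 2 to compound 3 (0.37 log units; beyond the scatter). Compound 3 therefore stands second of the three, well below compound 1 and somewhat above compound 2.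

Compound 4 `CCOc1cc(NC(=O)C2(NC(=O)c3ccc4c(C5CCCC5)c(-c5ncc(Cl)cn5)n(C)c4c3)CCC2)ccc1/C=C/C(=O)OCC(Cl)(Cl)Cl` keeps everything of compound 3 except that (trichloromethyl in place of ethyl on a saturated chain carbon bound to an oxygen next to a carbonyl group). Among the measured compounds shown here, none of the measured steps changes exactly this part: the steps into compound 2 and compound 3 alter the whole ester group, and both ester variants of this kind sit far below compound 1. The shown steps suggest that small esters at this position cluster in the short-lived range, so compound 4 is expected to stay near compound 3. The estimate for compound 4 is 0.4 h, within a range from 0.12 h to 1.5 h, which means an expected step of a 1.1-fold higher number from compound 3 to compound 4 (0.06 log units; within the scatter), within the scatter.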

Compound 4, half-life: 0.233 h
For compound 4 the middle estimate is 1.7-fold (0.23 log units) above the measured one; measured number inside the range.
By their numbers in this assay, from the lowest: compounds 2, 4 and 3 (each within the scatter of the next, the first and the last beyond it); then compound 1.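

Replacing ethyl with trichloromethyl on a saturated chain carbon bound to an oxygen next to a carbonyl group turns the propyl ester into the 2,2,2-trichloroethyl ester, yet in this assay this gives only a 1.5-fold lower number from compound 3 to compound 4 (0.18 log units; within the scatter), so this assay does not separate these two ester ends. Compound 4 also lies close to the phosphate-bearing ester, with a 1.6-fold higher number from compound 2 to compound 4 (0.19 log units; within the scatter), while the gap to the longest-lasting member is much larger, at a 34-fold lower number from compound 1 to compound 4 (1.53 log units; beyond the scatter); a third, quite different ester end thus joins the short-lived group, and only compound 1 stands apart, although compound 2 and compound 3 are themselves separated by slightly more than the scatter. Nothing available here explains why these ester ends give such similar numbers or why compound 1 differs so strongly.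

Going by these compounds, it remains open whether the long half-life of compound 1 needs both the carboxylic acid and the hydroxyl group of its ester end, which a simple 2-hydroxyethyl ester would help to test. On these data alone, how an ester ending in an amine or a longer chain such as hexyl would behave at this position also remains unknown.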